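The source may report more compounds than this note shows. Statements on the series, on what has been measured and on what is new or still open speak of the compounds shown alone.

Measured in an ADME assay on HEK-293T cells (Homo sapiens) for cytotoxicity, read by luminescence, with a stated time of 24 h (a lower number here means that less compound is tolerated, a higher number that more compound is tolerated), each value being a limit:
Compound 1 (`COc1ccc(Cn2c(C(N)=O)cc3sccc32)cc1`) gives > 100000 nM
Compound 2 (`CCCNC(=O)c1cc2sccc2n1Cc1ccc(OC)cc1`) gives > 100000 nM
Compound 3 (`COc1ccc(Cn2c(C(=O)N3CCCCC3)cc3sccc32)cc1`) gives > 100000 nM

Compound 3 stands at > 100000 nM which is a limit and not a number. Compound 1 and compound 2 also carry limits. Compound 4 (`COc1ccc(Cn2c(C(=O)N3CCNCC3)cc3sccc32)cc1`) has piperazin-1-yl in place of piperidin-1-yl on a carbonyl carbon. The measured steps that bear on this are a step that the two limits leave unreadable from compound 1 to compound 3 and a step that the two limits leave unreadable from compound 2 to compound 3 at that carbonyl carbon, along with a step that the two limits leave unreadable from compound 1 to compound 2 on the amide-type nitrogen. All three rest on one ceiling (the limit of > 100000 nM in this assay, at which 3 of the 3 values shown sit). None gives a size or a direction. The expected step (a number no higher from compound 3 to compound 4 (the limit leaves the size open)) is therefore none beyond the scatter in this assay. For compound 4 the estimated value is 100000 nM with an expected range from 50000 nM to 200000 nM and quite possibly again only a limit.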

Compound 4, half-maximal cytotoxic concentration: > 100000 nM
Compound 4 gave a limit, no number; the forecaster's own chance of this, stated with the estimate: 85%; the middle value lies on the limit itself.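

In this assay, going by these compounds alone, compound 4 gives > 100000 nM, which is a limit and not a number, so no step from compound 1, compound 2 or compound 3 to compound 4 can be read. The compounds shown leave open whether the group on the carbonyl carbon changes how much compound is tolerated: the limit of > 100000 nM in this assay, at which 4 of the 4 values shown sit.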